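Shorter link to the methoxycyclohexyl: the stereoisomer question

The compounds below may be only part of what the source reports. "The series", "measured", "known", "first", "only" and "open" are said of these compounds alone.

Measured so far:
compound 1, `COCCN1C(=O)CNc2ncc(-c3ccc(C(C)(C)O)nc3)nc21` — 91%
compound 2, `CO[C@H]1CC[C@@H](N2CC(=O)Nc3ncc(-c4ccc(C(C)(C)O)nc4)nc32)CC1` — 52%
compound 3, `CO[C@H]1CC[C@H](CN2CC(=O)Nc3ncc(-c4ccc(C(C)(C)O)nc4)nc32)CC1` — 64%

In a functional assay on the whole organism (PC-3 cells) for inhibition, with Mus musculus as the target, in a xenograft, with a stated time of 8 h, at a dose of 100 mg/kg by the oral route (on this read-out higher numbers stand for more inhibition at the one dose given (going by the name of the read-out) and lower numbers for less inhibition), compound 3 stands second of the three numbers, above compound 2 and well below compound 1. Compound 4, `CO[C@H]1CC[C@H](N2CC(=O)Nc3ncc(-c4ccc(C(C)(C)O)nc4)nc32)CC1`, differs from compound 3 in one place: 4-methoxycyclohexyl in place of (4-methoxycyclohexyl)methyl on a nitrogen on an aromatic ring in a ring. Going by the values given here, the one measured step that bears on this is a number 12 percentage points higher from compound 2 to compound 3 (beyond the scatter), which went the other way round. Compound 4 carries the same change in reverse, though with a different arrangement of the two stereocentres than compound 2, so the step is expected to fall back by a similar amount; the estimated step is a number 10 percentage points lower from compound 3 to compound 4 (within the scatter). Compound 4 is thus expected to give about 54%, within a range from 36% to 72%.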

Compound 4, a percentage reported as inhibition, in the whole organism at one dose (the size of the read-out at that dose, not a potency): 85%
The estimate for compound 4 lay 31 percentage points below the measured number; measured number outside the range, above it.
By their numbers in this assay, from the lowest: compound 2; then compound 3; then compounds 4 and 1 (each within the scatter of the next).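

On this nitrogen, 4-methoxycyclohexyl in place of (4-methoxycyclohexyl)methyl has no fixed direction in this assay: it gives a number 21 percentage points higher from compound 3 to compound 4 (beyond the scatter), whereas the reverse change gave a number 12 percentage points higher from compound 2 to compound 3 (beyond the scatter). The larger effect lies in the configuration of the ring, with a number 33 percentage points higher from compound 2 to compound 4 (beyond the scatter), and this step can be traced to stereochemistry alone: the fact that compounds 2 and 4 differ only in the configuration as drawn

The compounds shown leave open how the other configuration of the (4-methoxycyclohexyl)methyl group would read. They also leave open whether an amine or a carboxylic acid in place of the methoxy group on the cyclohexyl ring would hold the inhibition at this dose.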